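The source may hold more compounds than are shown below. What is called first, only, known or untested is meant among the compounds shown, and "the series" means these compounds.

In a functional assay on HCT-8 cells (Homo sapiens) for antiproliferative activity, read by MTT assay, with a stated time of 48 h (a lower number here means a stronger inhibitor, a higher number a weaker inhibitor), compound 3 `COc1ccc2c(/C=C/C(=O)c3cc(OC)c(OC)c(SC)c3)cn(C)c2c1` gives 157 nM, within the scatter of compound 1 `COc1ccc2c(/C=C/C(=O)c3cc(OC)c(OC)c(SC)c3)c[nH]c2c1` at 138 nM, whereas compound 2 `COc1ccc2c(/C=C/C(=O)c3cc(N)c(OC)c(OC)c3)cn(C)c2c1` gives 455 nM. Next is compound 4 `COc1ccc2c(/C=C/C(=O)c3cc(OC)c(OC)c([N+](=O)[O-])c3)cn(C)c2c1`, with nitro in place of methylsulfanyl on an aromatic carbon. The methyl on the aromatic nitrogen, a 1.1-fold higher number from compound 1 to compound 3 (0.06 log units; within the scatter), does not bear on this change. Going by the values given here, the relevant evidence is the single step at that aromatic carbon, a 2.9-fold lower number from compound 2 to compound 3 (0.46 log units; beyond the scatter), where compound 2 carries amino instead of methylsulfanyl. Nitro itself is untested in this series, so the direction is tentative. The expected move in this assay is a 3.2-fold higher number from compound 3 to compound 4 (0.50 log units; beyond the scatter), a modest step to a higher number. Compound 4 is estimated at 500 nM, with an expected range of 130 nM to 2000 nM.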

Compound 4, half-maximal inhibitory concentration: 753 nM
For compound 4 the middle estimate is 1.5-fold (0.18 log units) below the measured one; low and high end bracket the measured number.
By their numbers in this assay, from the lowest: compounds 1 and 3 (each within the scatter of the next); then compounds 2 and 4 (each within the scatter of the next).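

In this assay methylsulfanyl on this aromatic carbon now has a second replacement that gives a higher number: nitro brings a 4.8-fold higher number from compound 3 to compound 4 (0.68 log units; beyond the scatter) and so joins amino on the weaker side. Nitro and amino do not separate (a 1.7-fold higher number from compound 2 to compound 4 (0.22 log units; within the scatter)), so among these three groups methylsulfanyl alone stands apart, with the two nitrogen-bearing groups together. Nothing at hand explains this difference. Open, as far as these compounds go, is whether sulfur itself matters at this carbon: whether ethylsulfanyl, a longer chain, or a halogen such as chlorine would hold the number of compound 3 stays unanswered.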